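The compounds below may be only part of what the source reports. "The series", "measured", "known", "first", "only" and "open" are said of these compounds alone.

In a physicochemical assay for solubility, in phosphate buffer, measured as thermodynamic solubility, at pH 7.4 (a lower number here means a less soluble compound, a higher number a more soluble compound), three compounds on a shared core have been measured. Compound 1 `CNC(=O)CCc1cn(-c2ccc(Br)cc2)nc1-c1ccc(Cl)cc1` gives < 5000 nM, which is a limit of the assay and not a number. Compound 2 `CCS(=O)(=O)NC(=O)CCc1cn(-c2ccc(Br)cc2)nc1-c1ccc(Cl)cc1` gives 10000 nM. Compound 3 `Clc1ccc(-c2nn(-c3ccc(Br)cc3)cc2CCc2nnn[nH]2)cc1` gives 150000 nM, the highest number shown, and compound 2 is its nearest neighbour. Compound 4 `O=c1[nH]nc(CCc2cn(-c3ccc(Br)cc3)nc2-c2ccc(Cl)cc2)o1` departs from compound 3 in one place: a group of 6 heavy atoms (2 carbon, 2 nitrogen, 2 oxygen; one five-membered aromatic ring with 3 hetero atoms) in place of a group of 5 heavy atoms (1 carbon, 4 nitrogen; one five-membered aromatic ring with 4 hetero atoms), on a saturated chain carbon, two bonds along the chain from an aromatic carbon. The 1H-tetrazol-5-yl leaves its place on a saturated chain carbon, two bonds along the chain from an aromatic carbon.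

Among the measured compounds shown here, no measured step makes this exact replacement. For the measured compounds named here, two steps bear on it, and both are large and end at the group that leaves: an at least 30-fold higher number from compound 1 to compound 3 (1.47 log units; beyond the scatter), and a 15-fold higher number from compound 2 to compound 3 (1.18 log units; beyond the scatter). The third step, an at least 2.0-fold higher number from compound 1 to compound 2 (0.30 log units; that floor lies within the scatter), has a floor within the scatter. With compound 3 at the top at 150000 nM, and with a 15-fold higher number from compound 2 to compound 3 (1.18 log units; beyond the scatter) marking what that group has brought, a move downward in this assay is expected, though a smaller one than that step. The expected step is a 5.0-fold lower number from compound 3 to compound 4 (0.70 log units; beyond the scatter). The estimate for compound 4 is 30000 nM, with an expected range from 6000 nM to 120000 nM.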

Compound 4, solubility: < 5000 nM
Compound 4: no number, only a limit; the forecaster's own chance of this, stated with the estimate: 10%; middle value at least 6.0-fold (0.77 log units) away from the limit.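

In this assay, the high number of compound 3 does not carry over to every five-membered aromatic ring on a saturated chain carbon, two bonds along the chain from an aromatic carbon: an at least 30-fold lower number from compound 3 to compound 4 (1.47 log units; beyond the scatter), even though the entering ring has the same hydrogen-bond donor and acceptor counts as the 1H-tetrazol-5-yl. Against the (ethylsulfonyl)carbamoyl group, the same ring gives an at least 2.0-fold lower number from compound 2 to compound 4 (0.30 log units; that floor lies within the scatter), so this step does not clearly set the two groups apart. The step involving the methylcarbamoyl group of compound 1 cannot be read, as the values on both sides are limits: the limit of < 5000 nM in this assay, at which 2 of the 4 values shown sit.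

Going by these compounds, how far compound 1 and compound 4 lie under that limit stays open. So does how a carboxylic acid would stand at this place, and whether the 1H-tetrazol-5-yl would keep its number on a longer chain.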